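The source may hold more compounds than are shown below. What is called first, only, known or untested is meant among the compounds shown, and "the series" means these compounds.

Measured in an ADME assay on cells (Macrophage, Mus musculus) for cytotoxicity, read by resazurin assay, with a stated time of 3 days; a higher number here means a weaker inhibitor, a lower number a stronger inhibitor:
- Compound 1 `O=C(Nc1cc(C(F)(F)F)cc(C(F)(F)F)c1)c1cccc(Cl)c1`: > 60000 nM, a limit of the assay and not a number
- Compound 2 `O=C(Nc1cc(C(F)(F)F)cc(C(F)(F)F)c1)c1ccccc1`: "not determined" (no result reported)
- Compound 3 `O=C(Nc1cc(C(F)(F)F)cc(C(F)(F)F)c1)c1cc(F)ccc1O`: 2500 nM

Not yet measured: compound 4 `O=C(Nc1cccc(C(F)(F)F)c1)c1cc(F)ccc1O`.

Within the data shown here, compound 3, at 2500 nM, holds the only actual number in this assay, so it cannot be ranked within a spread of numbers. Compound 1 sits at a limit, seen in the limit of > 60000 nM in this assay, at which 1 of the 3 values shown sits. Compound 2 offers no comparison.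

The next change leads to compound 4: hydrogen in place of trifluoromethyl on an aromatic carbon, (hydrogen in place of trifluoromethyl on an aromatic carbon).

Among the measured compounds shown here, only one measured step is available, an at least 24-fold lower number from compound 1 to compound 3 (1.38 log units; beyond the scatter). It is large and beyond the scatter, but it is a change of 5-fluoro-2-hydroxyphenyl in place of 3-chlorophenyl on a carbonyl carbon, so it does not test the trifluoromethyl place. It shows that this assay can move strongly within this series, but it gives no direct size or direction for the present change. The expectation is therefore anchored on compound 3 at 2500 nM, with a wide margin.

A moderate shift towards a higher number is expected, a 2.2-fold higher number from compound 3 to compound 4 (0.34 log units; beyond the scatter), though a result within the scatter would not be surprising.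

For compound 4 the estimated value is 5500 nM, with an expected range of 1500 nM to 25000 nM.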

Compound 4, half-maximal inhibitory concentration: 6100 nM
Beside the measured number, compound 4's estimate is 1.1-fold (0.04 log units) below it, and the stated range covers the measured number.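

In this assay, among these compounds, this is the first direct reading of the trifluoromethyl place on an aromatic carbon: hydrogen in its stead gives a 2.4-fold higher number from compound 3 to compound 4 (0.39 log units; beyond the scatter), a modest step but one beyond the scatter, so the number does respond to this position. The earlier step, an at least 24-fold lower number from compound 1 to compound 3 (1.38 log units; beyond the scatter), concerned only the group on the carbonyl carbon and is large, whereas this change on the other aromatic ring moves the number less, and the 5-fluoro-2-hydroxyphenyl group stays constant across it. Nothing measured in this set gives a reason for the step.

Among the compounds shown here, the hydrogen-for-trifluoromethyl change is seen only with the 5-fluoro-2-hydroxyphenyl group on the carbonyl carbon, and steps involving compound 2 cannot be read, so it remains open whether the same shift would appear with the 3-chlorophenyl or unsubstituted phenyl group of the series. Also open, going by these compounds, is how this place would respond to a group other than hydrogen or trifluoromethyl, such as a nitrile or an amine, and whether either would carry the number further in the same direction or back towards that of compound 3.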